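This account rests on a few compounds, and the source may have more. Where it says the series, first, only, none or still open, it means among the compounds named here.

Working notes on the series. The compounds share one core and differ in what sits on the amine nitrogen of a six-membered non-aromatic ring with two nitrogen atoms. Compound 1 `CN(C[C@H]1Cc2c(cccc2N2CCNC(C)(C)C2)CN1)[C@H]1CCCc2cccnc21` gives 33.9 nM in a functional assay on CCRF-CEM cells for antagonist activity at C-X-C chemokine receptor type 4 (Homo sapiens), read by calcium flux, with stated times of 25 min and 90 s; on this read-out lower numbers stand for stronger inhibition and higher numbers for weaker inhibition. Compound 2 `CN(C[C@H]1Cc2c(cccc2N2CCN(c3ncccn3)CC2)CN1)[C@H]1CCCc2cccnc21` gives 30.7 nM in this assay. Within the data shown here, compound 2 has the lowest of the two numbers so far, but its gap to compound 1 is within the scatter, so the two cannot be ranked against each other; the two substituents on that ring nitrogen look interchangeable on this read-out.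

Compound 3 `CCN1CCN(c2cccc3c2C[C@H](CN(C)[C@H]2CCCc4cccnc42)NC3)CC1` is not yet measured. It differs from compound 2 by ethyl in place of pyrimidin-2-yl on an amine nitrogen in a ring. Among the measured compounds shown here, no pair of measured compounds isolates this exchange. For the measured compounds named here, the only hint is that compound 1, whose ring nitrogen carries no substituent, gives 33.9 nM, close to compound 2. For compound 3 the step of a 1.1-fold higher number from compound 2 to compound 3 (0.06 log units; within the scatter) is expected to be none beyond the scatter. Compound 3 is estimated at 35 nM, with a range of 12 nM to 100 nM.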

Compound 3, half-maximal inhibitory concentration: 13.8 nM
Estimate against measurement, compound 3: 2.5-fold (0.40 log units) above, and the stated range covers the measured number.
By their numbers in this assay, from the lowest: compound 3; then compounds 2 and 1 (each within the scatter of the next).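

The position is not as indifferent as compounds 1 and 2 suggested: in this assay, ethyl in place of pyrimidin-2-yl on the amine nitrogen gives a 2.2-fold lower number from compound 2 to compound 3 (0.35 log units; beyond the scatter), a modest step but the first at this ring nitrogen that lies beyond the scatter. Exchanging 3,3-dimethylpiperazin-1-yl on the aromatic carbon for 4-ethylpiperazin-1-yl gives a 2.5-fold lower number from compound 1 to compound 3 (0.39 log units; beyond the scatter), also modest, so compound 3 stands apart from both earlier compounds, which remain within the scatter of each other. Among these compounds, nothing measured so far accounts for these steps.

The exchange of pyrimidin-2-yl for ethyl removes an aromatic ring and heavy atoms together, and the compounds shown cannot say which of these changes goes with the lower number, or whether the ethyl result extends to any other group. Open questions are how a methyl, a longer chain such as propyl, or a 2-hydroxyethyl group on the same nitrogen would read out, and whether a phenyl ring there would behave like pyrimidin-2-yl.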